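A few compounds are considered here, and "the series" means these few. Any claim that something is new, unique, unknown or untested is made for them only; others in the source may bear on it.

Compound 2 `Fc1ccc(/C=N/NC(=S)Nc2cccc3ccccc23)c(F)c1` stands at the lowest of the two numbers recorded in a functional assay on A549 cells (Homo sapiens) for cytotoxicity, read by XTT assay, with a stated time of 24 h (a higher number here means a weaker inhibitor, a lower number a stronger inhibitor), where compound 2 gives 31.3 ug/mL. Among the compounds with values here, its nearest neighbour is compound 1 `Fc1cccc(F)c1/C=N/NC(=S)Nc1cccc2ccccc12`, which in this assay gives 500 ug/mL; the single step between them is a 16-fold lower number from compound 1 to compound 2 (1.20 log units; beyond the scatter). Compound 3 `Fc1cccc(Cl)c1/C=N/NC(=S)Nc1cccc2ccccc12` differs from compound 2 by 2-chloro-6-fluorophenyl in place of 2,4-difluorophenyl on a carbon with a double bond to nitrogen. Within the data shown here, only that one measured step bears on this change, and it was large. The 2-chloro-6-fluorophenyl of compound 3 resembles the 2,6-difluorophenyl of compound 1 more closely than the 2,4-difluorophenyl of compound 2, so a move back toward the number of compound 1 is expected. Compound 3 is therefore expected to show a higher number than compound 2, with an expected step of an 8.0-fold higher number from compound 2 to compound 3 (0.90 log units; beyond the scatter). In this assay compound 3 is estimated at 250 ug/mL, within a range from 60 ug/mL to 1000 ug/mL.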

Compound 3, half-maximal inhibitory concentration: 125 ug/mL
Compound 3: the middle estimate sits 2.0-fold (0.30 log units) above what was measured; low and high end bracket the measured number.
By their numbers in this assay, from the lowest: compound 2; then compound 3; then compound 1.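

In this assay the change from 2,4-difluorophenyl to 2-chloro-6-fluorophenyl gives a 4.0-fold higher number from compound 2 to compound 3 (0.60 log units; beyond the scatter) and so places a second group at this position above compound 2. Chloro in place of fluoro on an aromatic carbon gives a 4.0-fold lower number from compound 1 to compound 3 (0.60 log units; beyond the scatter) and shows that exchanging one halogen alone moves the number, which the earlier pair could not show. Compound 3 therefore falls between compound 2 and compound 1, with both steps beyond the scatter, and nothing given here accounts for either step.

As far as these compounds go, whether a bromo or methoxy group in place of that chloro would continue this order remains open. From the compounds shown here alone, it is also open whether an amine on this phenyl ring would bring the number closer to that of compound 2 or of compound 1.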